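The compounds below may be only part of what the source reports. "The series", "measured", "known", "first", "only" and "open" are said of these compounds alone.

Measured compounds:
compound 1, `COc1ccc(-c2cc(=O)c3c(OC)cc(OC)cc3n2S(=O)(=O)c2c(F)c(F)c(F)c(F)c2F)cc1`: "not determined" (no result reported)
compound 2, `COc1cc(OC)c2c(=O)cc(C(=O)Nc3ccc(N4CCN(C)CC4)cc3)[nH]c2c1`: > 19800 nM

The study concerns the antiproliferative read-out in a functional assay on UoC-B1 cells (Homo sapiens) for antiproliferative activity, with a stated time of 72 h; on this read-out higher numbers stand for an effect only at larger amounts of compound and lower numbers for an effect already at smaller amounts. Compound 1 carries a pentafluorophenylsulfonyl group on the ring nitrogen, and for it no result is reported. Within the data shown here, compound 2 is the only one with a value. In this assay compound 2 gives > 19800 nM, which is a limit of the assay and not a number. Compound 2 therefore stands at the limit of > 19800 nM in this assay, at which 1 of the 2 values shown sits, and no ordering against any other compound can be drawn from it.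

Compound 3, `COc1cc(OC)c2c(=O)cc(C(=O)Nc3ccc(-n4cccc4)cc3)[nH]c2c1`, is not yet measured. The change is 1H-pyrrol-1-yl in place of 4-methylpiperazin-1-yl on an aromatic carbon. Among the measured compounds shown here, no step between measured compounds is available, so the expected size of the step rests on compound 2 alone. Since compound 2 reports only a limit, the estimate for compound 3 is expected to lie near that same limit, with the step that the limit leaves unreadable from compound 2 to compound 3 expected to be none beyond the scatter. Compound 3 is estimated at 20000 nM, in a range from 5000 nM to 60000 nM.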

Compound 3, half-maximal effective concentration: 51800 nM
Estimate against measurement, compound 3: 2.6-fold (0.41 log units) below; the measured number falls inside the stated range.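

In this assay, among these compounds, compound 2 gives > 19800 nM, which is a limit and not a number, so no step from it to compound 3 can be read. The compounds shown leave open how much 1H-pyrrol-1-yl in place of 4-methylpiperazin-1-yl changes the antiproliferative effect, and whether any change to the shared core brings that effect to smaller amounts of compound.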